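Trimming the Amine: From tert-Butyl to Ethyl(methyl)

This account rests on a few compounds, and the source may have more. Where it says the series, first, only, none or still open, it means among the compounds named here.

Of the compounds shown here, three sharing one core have been tested in a functional assay on the whole organism with Rattus norvegicus as the target, in the maximal electroshock model; on this read-out higher numbers stand for an effect only at larger amounts of compound and lower numbers for an effect already at smaller amounts. Compound 1 `CNc1ncnc2c1ncn2Cc1ccccc1C(F)(F)F` carries a methylamino group and gives 20 mg/kg. Compound 2 `CCCNc1ncnc2c1ncn2Cc1ccccc1F` carries a propylamino group and gives 5.1 mg/kg. Compound 3 `CC(C)(C)Nc1ncnc2c1ncn2Cc1ccccc1F` carries a (tert-butyl)amino group, and for compound 3 the result is > 50 mg/kg, which is a limit of the assay rather than a number. From the compounds shown here alone, compound 3 therefore stands at that limit, and its true position is unknown; what is recorded is the limit of > 50 mg/kg in this assay, at which 1 of the 3 values shown sits.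

Compound 4 `CCN(C)c1ncnc2c1ncn2Cc1ccccc1F` differs from compound 3 in one place: ethyl(methyl)amino in place of (tert-butyl)amino on an aromatic carbon. Among the measured compounds shown here, the only measured step at this position is an at least 9.8-fold higher number from compound 2 to compound 3 (0.99 log units; beyond the scatter), in which the bulkier group brought a clearly higher number. For the measured compounds named here, the change to compound 4 removes that tert-butyl branching, yet the entering group has no hydrogen-bond donor, and no measured step shows what such a loss does. The expectation is a step toward a lower number, of uncertain size, so that the estimated at least 3.3-fold lower number from compound 3 to compound 4 (0.52 log units; beyond the scatter) is moderate rather than large. Compound 4 is therefore expected to give around 15 mg/kg, with a likely range from 5 mg/kg to 50 mg/kg.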

Compound 4, dose for half-maximal effect: 2.9 mg/kg
The estimate for compound 4 lay 5.2-fold (0.71 log units) above the measured number; measured number outside the range, below it.
By their numbers in this assay, from the lowest: compounds 4 and 2 (each within the scatter of the next); then compound 1. At a limit, above all of these: compound 3.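

In this assay, the change to ethyl(methyl)amino gives an at least 17-fold lower number from compound 3 to compound 4 (1.23 log units; beyond the scatter), so a high number is not fixed at this place on the shared core: it goes with (tert-butyl)amino, not with every group on this aromatic carbon that is larger than a simple methylamino. From the compounds shown here alone, the result for compound 3 is a limit of the assay and not a number, so the true size of that step is unknown and only its lower bound can be read: the limit of > 50 mg/kg in this assay, at which 1 of the 4 values shown sits. The comparison with propylamino gives a 1.8-fold lower number from compound 2 to compound 4 (0.25 log units; within the scatter), a step within the scatter, which shows that ethyl(methyl)amino, with no hydrogen-bond donor, does as well as propylamino here, so a low number at this position does not depend on keeping a hydrogen on the amine nitrogen.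

Going by these compounds, whether dimethylamino, or a ring amine such as pyrrolidine or morpholine, would also keep the number low on this core remains open. Also open, on these data alone, is how the methylamino group of compound 1 would fare alongside the rest of compound 4, as compound 1 differs from it in more than one place.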